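The source may report more compounds than this note shows. Statements on the series, on what has been measured and on what is new or still open speak of the compounds shown alone.

Working notes on the series in a functional assay on MCF7 cells (Homo sapiens) for antiproliferative activity; on this read-out higher numbers stand for weaker inhibition and lower numbers for stronger inhibition.

Compound 1 `O=[N+]([O-])c1ccccc1S(=O)(=O)N1CC(n2cnc3ncnc(Sc4ccccc4)c32)OCc2ccccc21` gives 2590 nM in this assay. Compound 3 `O=[N+]([O-])c1ccc(S(=O)(=O)N2CC(n3cnc4ncnc(Sc5ccccc5)c43)OCc3ccccc32)cc1` differs from compound 1 by 4-nitrophenyl in place of 2-nitrophenyl on a sulfonyl sulfur and in this assay compound 3 gives 860 nM; the step of a 3.0-fold lower number from compound 1 to compound 3 (0.48 log units; beyond the scatter). Compound 2 `O=[N+]([O-])c1ccccc1S(=O)(=O)N1CC(n2cnc3c(Cl)ncnc32)OCc2ccccc21` stands on a different core; the difference between the core of compound 2 and the core of compound 1 is not broken down here. In this assay compound 2 gives 2100 nM, a value within the scatter of that of compound 1 and beyond the scatter relative to compound 3.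

Compound 4 `O=[N+]([O-])c1ccc(S(=O)(=O)N2CC(n3cnc4c(Cl)ncnc43)OCc3ccccc32)cc1` has not yet been measured. It differs from compound 2 by 4-nitrophenyl in place of 2-nitrophenyl on a sulfonyl sulfur. This is the same change as that from compound 1 to compound 3, at the same place, a sulfonyl sulfur whose other neighbour is a sulfonamide nitrogen in a ring. Within the data shown here, the step from compound 2 to compound 4 is expected to be a 3.0-fold lower number from compound 2 to compound 4 (0.48 log units; beyond the scatter) because the single measured step of a 3.0-fold lower number from compound 1 to compound 3 (0.48 log units; beyond the scatter) is the only guide for this change, and the two cores differ, so the range is kept wide. Compound 4 is therefore estimated at about 700 nM in this assay. The estimated range for compound 4 runs from 300 nM to 1600 nM.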

Compound 4, half-maximal inhibitory concentration: 2730 nM
Compound 4: the middle estimate sits 3.9-fold (0.59 log units) below what was measured; measured number outside the range, above it.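

On the core of compound 2, in this assay, 4-nitrophenyl in place of 2-nitrophenyl on a sulfonyl sulfur gives a 1.3-fold higher number from compound 2 to compound 4 (0.11 log units; within the scatter), so this change has no readable effect on that core. A step measured on one core therefore cannot simply be carried over to the other in this series: the same change on two cores in this assay, a 3.0-fold lower number (0.48 log units; beyond the scatter) from compound 1 to compound 3 and a 1.3-fold higher number (0.11 log units; within the scatter) from compound 2 to compound 4, 3.9-fold (0.59 log units) apart, beyond the scatter of two such steps These two pairs do not show which difference between the cores goes with this gap, and with a single pair on each core they cannot show how the change would behave on a third core.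

Left open is what happens with an amine or a methoxy group where compound 2 carries chlorine, and whether the step between 2-nitrophenyl and 4-nitrophenyl would then resemble the one seen on the core of compound 1 or the one seen on the core of compound 2. Also open, from the compounds shown here alone, is whether a carboxylic acid or an amide in place of the nitro group on the phenyl ring would give a step that holds on both cores.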